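A few compounds are considered here, and "the series" means these few. Any claim that something is new, unique, unknown or untested is made for them only; others in the source may bear on it.

Of the compounds shown here, two have numbers so far. Compound 1 `CC1=C(C(=O)OC(C)C)C(c2cccc([N+](=O)[O-])c2)NC(=S)N1` gives 15800 nM in an assay on HEK293 cells for antagonist activity at Voltage-dependent L-type calcium channel subunit alpha-1D (Rattus norvegicus), read by FLIPR; a higher number here means a weaker inhibitor, a lower number a stronger inhibitor. Compound 2 `COC(=O)N1C(=O)NC(C)=C(C(=O)OC(C)C)C1c1cccc([N+](=O)[O-])c1` gives 2960 nM in this assay, the lower of the two, and its gap to compound 1 lies beyond the usual scatter. Compound 3 `CC1=C(C(=O)OC(C)C)C(c2cccc([N+](=O)[O-])c2)N(C(=O)OC(C)C)C(=O)N1` awaits measurement. It differs from compound 2 in one place: isopropyl in place of methyl on an oxygen next to a carbonyl group. Within the data shown here, no measured pair shows this change, so nothing here tells its size. Only a small step is expected, a 1.0-fold higher number from compound 2 to compound 3 (0.01 log units; within the scatter) in this assay, not clearly beyond the scatter. Compound 3 is estimated at 3000 nM, in a range from 1200 nM to 8000 nM.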

Compound 3, half-maximal inhibitory concentration: 660 nM
Beside the measured number, compound 3's estimate is 4.5-fold (0.66 log units) above it, outside the stated range (below it).
By their numbers in this assay, from the lowest: compound 3; then compound 2; then compound 1.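

Replacing methoxycarbonyl with isopropoxycarbonyl gives a 4.5-fold lower number from compound 2 to compound 3 (0.65 log units; beyond the scatter) in this assay. Among these compounds, no earlier pair had tested this change, and this one shows that the number at this position responds to the group on the oxygen, with isopropyl giving the stronger inhibitor of the two. No supporting measurement explains why the number falls. With only methyl and isopropyl compared here, the trend cannot be judged. From the compounds shown here alone, it remains open whether a longer chain such as butyl, or a cyclic group such as cyclohexyl, would lower the number further or raise it again.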